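This account rests on a few compounds, and the source may have more. Where it says the series, first, only, none or still open, it means among the compounds named here.

Series values in a functional assay on ZR-75-1 cells (Homo sapiens) for inhibition, read by sulforhodamine B assay; on this read-out lower numbers stand for stronger inhibition of growth and higher numbers for weaker inhibition of growth:

- compound 1 `FC(F)(F)Oc1ccc(-c2ccc(-c3ccc(-c4nc5ccccc5[nH]4)cc3)cc2)cc1`: 100000 nM
- compound 2 `Oc1cccc2[nH]c(-c3ccc(-c4ccc(-c5ccc(OC(F)(F)F)cc5)cc4)cc3)nc12`: 3800 nM
- compound 3 `Cc1ccc2[nH]c(-c3ccc(-c4ccc(-c5ccccc5)cc4)cc3)nc2c1`: 27400 nM

Compound 3, at 27400 nM, holds the middle place of the three numbers, under compound 1 and over compound 2. Next in line is compound 4 `Cc1ccc2[nH]c(-c3ccc(-c4ccc(-c5ccc(OC(F)(F)F)cc5)cc4)cc3)nc2c1`, which carries trifluoromethoxy in place of hydrogen on an aromatic carbon.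

Among the measured compounds shown here, no measured step isolates this change. For the measured compounds named here, the only step available, a 26-fold lower number from compound 1 to compound 2 (1.42 log units; beyond the scatter), is large, but it is a different change, hydroxy in place of hydrogen. Going by the values given here, it shows only that numbers can move far between compounds that both carry trifluoromethoxy. That group does not guarantee a low number, since compound 1 stands at 100000 nM and compound 2 at 3800 nM. A modest move towards a lower number is therefore expected, with a wide margin, and no move beyond the scatter remains possible. The estimated step is a 1.7-fold lower number from compound 3 to compound 4 (0.23 log units; within the scatter). For compound 4 the expected value is 16000 nM, with an estimated range of 4000 nM to 60000 nM.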

Compound 4, concentration for 50% growth inhibition: 2410 nM
For compound 4 the middle estimate is 6.6-fold (0.82 log units) above the measured one, and the stated range ends above it.
By their numbers in this assay, from the lowest: compounds 4 and 2 (each within the scatter of the next); then compound 3; then compound 1.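

In this assay, the position para to a large group on the outer six-membered aromatic ring responds strongly: an 11-fold lower number from compound 3 to compound 4 (1.06 log units; beyond the scatter) shows that trifluoromethoxy in place of hydrogen on an aromatic carbon matters in the methyl-bearing compounds. Methyl in place of hydrogen on an aromatic carbon, with trifluoromethoxy kept, gives a 41-fold lower number from compound 1 to compound 4 (1.62 log units; beyond the scatter), so a large step from compound 1 is not confined to hydroxy. Exchanging 4-hydroxy-1H-benzimidazol-2-yl for 5-methyl-1H-benzimidazol-2-yl gives a 1.6-fold lower number from compound 2 to compound 4 (0.20 log units; within the scatter), which lies within the scatter, so these two groups cannot be told apart here.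

Going by these compounds, whether an amine or a carboxylic acid at the place of trifluoromethoxy would hold the number near that of compound 4 stays open. Nothing available accounts for the size of these steps.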